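This account rests on a few compounds, and the source may have more. Where it says the series, first, only, none or still open, it means among the compounds named here.

Working notes on the amide series. Three members share one core and differ only in the aryl group on the amide nitrogen. In a functional assay on the whole organism (strain Wistar) for inhibition, with Rattus norvegicus as the target, read by paw edema, with a stated time of 1 h, at a dose of 100 mg/kg (on this read-out lower numbers stand for less inhibition and higher numbers for more inhibition at the one dose given (going by the name of the read-out)), compound 2 `COc1cc2c(cc1OC)C(CC(=O)Nc1ccccc1C)CC2` gives 21.9%. That is the smallest of the three numbers, but the gap to compound 1 `COc1cc2c(cc1OC)C(CC(=O)Nc1cccc(Cl)c1)CC2`, which in this assay gives 31.3%, is within the scatter; only compound 3 `COc1cc2c(cc1OC)C(CC(=O)Nc1ccc([N+](=O)[O-])cc1)CC2`, which gives 37.5% in this assay, stands beyond the scatter from compound 2.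

Going by the values given here, the one measured step that changes the aryl group on the amide nitrogen is a number 9.4 percentage points lower from compound 1 to compound 2 (within the scatter), a step of no weight.

Compound 4 `COc1cc2c(cc1OC)C(CC(=O)Nc1ccccn1)CC2` is not yet measured. It differs from compound 2 in one place: pyridin-2-yl in place of 2-methylphenyl on an amide-type nitrogen. Among the compounds with values here, the only step that bears on this change is the aryl exchange from compound 1 to compound 2, and it stayed within the scatter. Within the data shown here, no measured step brings a ring nitrogen into the aryl group, so nothing points to a move in either direction in this assay. The expectation is therefore a step of a number 3.1 percentage points higher from compound 2 to compound 4 (within the scatter), within the scatter. Compound 4 is estimated at 25%, with a range from 12% to 40%.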

Compound 4, a percentage reported as inhibition, in the whole organism at one dose (the size of the read-out at that dose, not a potency): 25%
For compound 4 middle estimate and measured number coincide at the digits printed, within the range that was stated.
By their numbers in this assay, from the lowest: compounds 2, 4, 1 and 3 (each within the scatter of the next, the first and the last beyond it).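

In this assay, going by these compounds alone, this position on the amide-type nitrogen now carries a ring nitrogen for the first time: pyridin-2-yl, with its one hydrogen-bond acceptor, replaces the carbon-only 2-methylphenyl, a step of a number 3.1 percentage points higher from compound 2 to compound 4 (within the scatter). Set against the other carbon-only aryl group, the exchange reads a number 6.3 percentage points lower from compound 1 to compound 4 (within the scatter), so neither measured step of this change leaves the scatter, and at this position and in this read-out, the ring nitrogen cannot be told apart from either the 2-methylphenyl or the 3-chlorophenyl group. No measurement is at hand that would explain the absence of a clear step, or tie the number for compound 4 to any property of the pyridin-2-yl group.

The compounds shown leave open whether a group of another kind on the amide-type nitrogen, such as a benzyl or cyclohexyl group in place of the directly attached aromatic ring, would move the number beyond the scatter. They also leave open what a carboxylic acid or an amine on the pyridine ring would do in this assay, since the pyridin-2-yl group appears here only without further groups.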